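Swapping bromo for nitro in a weak growth inhibitor

The compounds below may be only part of what the source reports. "The series", "measured", "known", "first", "only" and "open" are said of these compounds alone.

In a functional assay on OVCAR-3 cells (Homo sapiens) for inhibition, read by sulforhodamine B assay, with a stated time of 48 h (a lower number here means a stronger inhibitor of growth, a higher number a weaker inhibitor of growth), compound 1 (`CCOC(=O)c1nn(-c2ccccc2)c(-c2ccc(F)cc2)c1CNC(C)(C)C`) gives 13 nM; 92100 nM (2 entries), two entries lying far apart. Compound 2 (`CCOC(=O)c1nn(-c2ccccc2)c(-c2ccc(Br)cc2)c1CNC(C)(C)C`) gives 2910 nM; > 509000 nM (2 entries), two entries that also lie far apart. Compound 3 (`CC(C)(C)NCc1c(C(=O)O)nn(-c2ccccc2)c1-c1ccc(Br)cc1`) has only > 585000 nM, which is a limit and not a number. Compound 4 (`CC(C)(C)NCc1c(C(=O)O)nn(-c2ccccc2)c1-c1ccc([N+](=O)[O-])cc1`) differs from it at one place, with nitro in place of bromo on an aromatic carbon, para to a large group (nitro in place of bromo on an aromatic carbon). The limit of compound 3, > 585000 nM, is the closest guide, so no shift beyond the scatter is expected in this assay. The estimated change an at least 1.0-fold lower number from compound 3 to compound 4 (0.02 log units; that floor lies within the scatter) is therefore small. Compound 4 is expected at 550000 nM, with an estimated range of 80000 nM to 700000 nM.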

Compound 4, concentration for 50% growth inhibition: > 634000 nM
Compound 4 ended at the assay's limit (the forecaster's own chance of this, stated with the estimate: 70%); middle value at least 1.1-fold (0.06 log units) away from the limit.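

Compound 3 and compound 4 both end at a limit of this assay, so no step can be read between them. The compounds shown leave open whether nitro in place of bromo changes growth inhibition at all.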